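A few compounds are considered here, and "the series" means these few. Any claim that something is new, unique, unknown or untested is made for them only; others in the source may bear on it.

Measured in a functional assay on A549 cells (Homo sapiens) for cytotoxicity, read by MTT assay, with a stated time of 48 h; a higher number here means a weaker inhibitor, a lower number a stronger inhibitor:

Compound 1 `COc1ccc(CN(C(=O)Nc2ccc(Cl)cc2)n2cnnc2)cc1OC` gives 44200 nM in this assay.
Compound 2 `COc1ccc(CN(C(=O)Nc2ccc(C#N)cc2)n2cnnc2)cc1OC` does not reach a number in this assay; its value, > 50000 nM, is a limit of the assay.
Compound 3 `Cc1ccsc1CN(C(=O)Nc1cccc(Cl)c1)n1cnnc1` gives 21400 nM in this assay.

Compound 4 `Cc1ccsc1CN(C(=O)Nc1cccc(C#N)c1)n1cnnc1` has not yet been measured in this assay.

Compound 1 and compound 3 carry different cores; the difference between the two cores is not broken down here. Of the two numbers available, compound 3 stands lowest, with compound 1 giving a higher number beyond the usual scatter.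

Going by the values given here, the one change with a measured step is cyano in place of chloro on an aromatic carbon. Its size is an at least 1.1-fold higher number from compound 1 to compound 2 (0.05 log units; that floor lies within the scatter); the step is only a floor because compound 2 sits at the limit of > 50000 nM in this assay, at which 1 of the 3 values shown sits. The change planned for compound 4 is cyano in place of chloro on an aromatic carbon. Around the place the two pairs differ: in the first the group sits para to a large group, in the second meta to a large group, so this is the same kind of change rather than the same change.

What to expect for compound 4 rests on the step seen between compound 1 and compound 2, an at least 1.1-fold higher number from compound 1 to compound 2 (0.05 log units; that floor lies within the scatter), a floor that points toward a higher number. From compound 3 to compound 4 a step of a 1.5-fold higher number from compound 3 to compound 4 (0.17 log units; within the scatter) is expected. Compound 4 is therefore estimated at 32000 nM in this assay, with a range from 15000 nM to 70000 nM, and a limit rather than a number is possible.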

Compound 4, half-maximal inhibitory concentration: 26000 nM
Compound 4: middle estimate off by 1.2-fold (0.09 log units), on the high side; the range from low to high includes it.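

In this assay, cyano in place of chloro on the core of compound 3 gives a 1.2-fold higher number from compound 3 to compound 4 (0.08 log units; within the scatter), so 3-chlorophenyl to 3-cyanophenyl leaves no step beyond the scatter on this core. Set beside the earlier step, this shows that the change has been tried on two cores, but not that it carries over with the same size, and the two pairs also place the group differently, so they hold the same kind of change rather than the same change: the same change on two cores in this assay, an at least 1.1-fold higher number (0.05 log units; that floor lies within the scatter) from compound 1 to compound 2 and a 1.2-fold higher number (0.08 log units; within the scatter) from compound 3 to compound 4; the limit leaves it open whether they differ. Compound 2 gives a limit of the assay and not a number, so its step remains a floor: the limit of > 50000 nM in this assay, at which 1 of the 4 values shown sits.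

The compounds shown carry only chloro or cyano at this place, so the effect of an amine, a carboxylic acid or a longer chain there remains open in this assay. As far as these compounds go, it also remains open whether any replacement at this place gives a step beyond the scatter on either core, and a firm comparison of the two cores would need a number for compound 2 rather than a limit.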